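This account rests on a few compounds, and the source may have more. Where it says the series, first, only, none or still open, it means among the compounds named here.

Measured compounds:
compound 1 `CC(C)C(c1ccc(-c2ccc3cccc(F)c3c2)[nH]c1=O)N1CCN/C1=N\C#N` — 23 nM
compound 2 `CC(C)C(Cc1nnn[nH]1)c1ccc(-c2ccc3cccc(F)c3c2)[nH]c1=O` — 34 nM

In an assay on CHO cells for displacement of a labelled ligand from prostaglandin E2 receptor EP3 subtype (Homo sapiens), read by radioligand binding (a higher number here means a weaker inhibitor, a lower number a stronger inhibitor), compound 2 gives 34 nM, the higher of the two numbers shown, and its only neighbour is compound 1 at 23 nM; the step of a 1.5-fold higher number from compound 1 to compound 2 (0.17 log units; within the scatter) lies within the scatter, so the two cannot be ordered. Compound 3 `CC(C)NC(=O)CC(c1ccc(-c2ccc3cccc(F)c3c2)[nH]c1=O)C(C)C` continues from compound 2 with isopropylcarbamoyl in place of 1H-tetrazol-5-yl on a saturated chain carbon, two bonds along the chain from an aromatic carbon. For the measured compounds named here, the one measured step that bears on this place, a 1.5-fold higher number from compound 1 to compound 2 (0.17 log units; within the scatter), shows that exchanging the group on this chain carbon left the number essentially unchanged, but neither of the measured groups is an isopropylcarbamoyl, so the new change has no direct precedent. On that evidence a small to moderate rise, and possibly none beyond the scatter, is expected. Compound 3 is therefore estimated at 60 nM, with a range of 15 nM to 250 nM, meaning an expected step of a 1.8-fold higher number from compound 2 to compound 3 (0.25 log units; within the scatter).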

Compound 3, inhibition constant: 5.8 nM
Compound 3: the middle estimate sits 10-fold (1.01 log units) above what was measured; the whole stated range lies above it.
By their numbers in this assay, from the lowest: compound 3; then compounds 1 and 2 (each within the scatter of the next).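

In this assay, for the compounds shown here, the exchange of 1H-tetrazol-5-yl for isopropylcarbamoyl gives a 5.9-fold lower number from compound 2 to compound 3 (0.77 log units; beyond the scatter) and is the first change at this saturated chain carbon to move the number beyond the scatter. Set against the group in compound 1, the group in compound 3 gives a 4.0-fold lower number from compound 1 to compound 3 (0.60 log units; beyond the scatter) as well, so among these three compounds the open-chain group without a ring gives the lowest number, while the two ring-bearing groups cannot be ordered. The compounds shown come with no measurement that could account for this difference.

On these data alone, it remains open whether the isopropyl part or the carbonyl and the amide hydrogen carry the change. A primary carboxamide, a carboxylic acid or a tert-butyl amide on the same chain carbon would bear on that question.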